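A few compounds are considered here, and "the series" means these few. Any claim that something is new, unique, unknown or untested is made for them only; others in the source may bear on it.

Compound 1 `CCC1(Cc2ccccc2)OS(=O)(=O)C=C1OCc1ccc(Cl)cc1` was examined in an ADME assay on HEL cells (Homo sapiens) for cytotoxicity, with a stated time of 3 days; on this read-out higher numbers stand for lower toxicity in this test and lower numbers for higher toxicity in this test. In this assay compound 1 gives >= 50000 nM, a limit rather than a number. Compound 2 `CC(C)CC1(Cc2ccccc2)OS(=O)(=O)C=C1OCc1ccccc1` gives >= 80000 nM, also a limit. Compound 3 `CC1(C(c2ccccc2)c2ccccc2)OS(=O)(=O)C=C1OCc1ccccc1` gives >= 400000 nM, again a limit. Since all three values are limits, compound 1 cannot be ordered against the others. Compound 4 `CCC1(Cc2ccccc2)OS(=O)(=O)C=C1OCc1ccc(Br)cc1` has not been measured; it differs from compound 1 by bromo in place of chloro on an aromatic carbon. Within the data shown here, no measured pair here differs in a single place, so no measured step guides the comparison. No shift beyond the usual scatter is expected, and the step is estimated at a number no higher from compound 1 to compound 4 (the limit leaves the size open). Compound 4 is therefore expected to give about 50000 nM, between 25000 nM and 100000 nM, most probably again as a limit.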

Compound 4, minimum cytotoxic concentration: 80000 nM
For compound 4 the middle estimate is 1.6-fold (0.20 log units) below the measured one; measured number inside the range.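

The step from compound 1 to compound 4 cannot be read, as compound 1 stands only as a limit in this assay. The compounds shown leave open whether bromo in place of chloro shifts this read-out at all.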